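Carbonyl substituent swap on a fused thiadiazine core

A few compounds are considered here, and "the series" means these few. Any claim that something is new, unique, unknown or untested is made for them only; others in the source may bear on it.

Measured compounds:
- compound 1, `COc1cc(-c2nnc3n2NC(c2ccco2)C(C(=O)C2CC2)S3)cc(OC)c1OC`: 95200 nM
- compound 2, `COc1cc(C(=O)C2Sc3nnc(-c4cc(OC)c(OC)c(OC)c4)n3NC2c2cccs2)cc(OC)c1OC`: > 100000 nM
- compound 3, `COc1ccc(C(=O)C2Sc3nnc(-c4cc(OC)c(OC)c(OC)c4)n3NC2c2cccs2)cc1`: 95900 nM

Three compounds share one core and differ in the group on the carbonyl carbon. In a functional assay on PC-3 cells (Homo sapiens) for cytotoxicity, read by MTT assay, with a stated time of 48 h (a lower number here means a stronger inhibitor, a higher number a weaker inhibitor), compound 1 gives 95200 nM, the lowest of the two numbers shown. Compound 3 gives 95900 nM in this assay, which sits within the scatter of compound 1. For compound 2 this assay reports only a limit, > 100000 nM, as the limit of > 100000 nM in this assay, at which 1 of the 3 values shown sits, records. For the measured compounds named here, the single measured step at the carbonyl carbon, an at least 1.0-fold lower number from compound 2 to compound 3 (0.01 log units; that floor lies within the scatter), stays within the scatter.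

Compound 4, `COc1cc(-c2nnc3n2NC(c2ccco2)C(C(=O)c2ccc(C(F)(F)F)cc2)S3)cc(OC)c1OC`, is not yet measured. It differs from compound 1 by 4-(trifluoromethyl)phenyl in place of cyclopropyl on a carbonyl carbon. Going by the values given here, the one step that bears on this position, from compound 2 to compound 3, showed no movement beyond the scatter, so no step beyond the scatter is expected here either: the step from compound 1 to compound 4 is estimated as a 1.1-fold lower number from compound 1 to compound 4 (0.02 log units; within the scatter). Compound 4 is therefore expected to give about 90000 nM in this assay, within a range from 35000 nM to 250000 nM.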

Compound 4, half-maximal inhibitory concentration: 77500 nM
For compound 4 the middle estimate is 1.2-fold (0.06 log units) above the measured one; the measured number falls inside the stated range.
By their numbers in this assay, from the lowest: compounds 4, 1 and 3 (each within the scatter of the next). At a limit, above all of these: compound 2.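

The earlier step at this position exchanged one substituted phenyl group for another, whereas this one replaces cyclopropyl, a three-membered non-aromatic ring, with 4-(trifluoromethyl)phenyl, a six-membered aromatic ring with more heavy atoms. Even so, this assay gives a 1.2-fold lower number from compound 1 to compound 4 (0.09 log units; within the scatter), so on the core of compound 1 the carbonyl carbon takes either a small saturated ring or a substituted aromatic ring with no difference beyond the scatter. The data shown offer no explanation for this flat result.

Going by these compounds, whether an amine or a carboxylic acid on the carbonyl carbon would move the number beyond the scatter remains open. Also open, on these data alone, is whether the same exchange would read alike on the core of compound 3.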